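From a pyridin-4-yl amide to a phenyl amide

The source may report more compounds than this note shows. Statements on the series, on what has been measured and on what is new or still open speak of the compounds shown alone.

Measured in a functional assay on HCT-15 cells (Homo sapiens) for antiproliferative activity; a lower number here means a stronger inhibitor, a higher number a weaker inhibitor:
Compound 1 `COc1ccc(S(=O)(=O)Oc2ccccc2NC(=O)c2ccncc2)cc1` gives 89 nM
Compound 2 `COc1ccc(S(=O)(=O)Oc2ccccc2NC(=O)c2ccc3ncccc3c2)cc1` gives > 10000 nM, a limit
Compound 3 `COc1ccc(S(=O)(=O)Oc2ccccc2NC(=O)c2ccnc3ccccc23)cc1` gives > 10000 nM, a limit

Compound 3 has no number, only (the limit of > 10000 nM in this assay, at which 2 of the 3 values shown sit). Compound 4 `COc1ccc(S(=O)(=O)Oc2ccccc2NC(=O)c2ccccc2)cc1` carries phenyl in place of quinolin-4-yl on a carbonyl carbon, and the difference is phenyl in place of quinolin-4-yl on a carbonyl carbon. Going by the values given here, two measured steps bear on this change. The first is an at least 110-fold higher number from compound 1 to compound 2 (2.05 log units; beyond the scatter), for quinolin-6-yl in place of pyridin-4-yl. The second is an at least 110-fold higher number from compound 1 to compound 3 (2.05 log units; beyond the scatter), for quinolin-4-yl in place of pyridin-4-yl. Both steps were large, and both end at a limit, so they fix only one side of the picture. Compound 4 keeps a single six-membered aromatic ring on the carbonyl carbon, as compound 1 does with 89 nM, so some recovery in this assay is expected, though phenyl has not been tested here. The expected change is an at least 6.6-fold lower number from compound 3 to compound 4 (0.82 log units; beyond the scatter), towards a lower number, and it remains uncertain. For compound 4 the estimated value is 1500 nM, with an expected range from 150 nM to 10000 nM.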

Compound 4, half-maximal inhibitory concentration: 310 nM
Beside the measured number, compound 4's estimate is 4.8-fold (0.68 log units) above it; low and high end bracket the measured number.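

In this assay, the large loss seen with the quinolinyl amides does not come from leaving pyridin-4-yl alone, since phenyl on the carbonyl carbon restores most of the activity: an at least 32-fold lower number from compound 3 to compound 4 (1.50 log units; beyond the scatter), and an at least 32-fold lower number from compound 2 to compound 4 (1.50 log units; beyond the scatter). The nitrogen of pyridin-4-yl is not essential here, yet it still counts for something, as the modest step shows: a 3.5-fold higher number from compound 1 to compound 4 (0.54 log units; beyond the scatter). Compound 2 and compound 3 remain limits of the assay, not numbers: the limit of > 10000 nM in this assay, at which 2 of the 4 values shown sit.

How far compound 2 and compound 3 lie from each other cannot be read. Open too, going by these compounds, is whether the ring nitrogen must sit where it does in pyridin-4-yl, as pyridin-3-yl or pyridin-2-yl would show, and how phenyl carrying a methoxy group or an amine would fare.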